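The compounds below may be only part of what the source reports. "The series", "measured", "known", "first", "only" and "open" are said of these compounds alone.

Measured so far:
compound 1 `CCOC(=O)c1nn(-c2ccc(Cl)cc2)c(-c2ccc(OC)cc2OC)c1C` — 0%
compound 2 `COc1ccc(C2=NNCC2C)c(OC)c1` — 20%
compound 3 `COc1ccc(C2=NN(C(=O)NS(=O)(=O)c3ccc(C)cc3)CC2C)c(OC)c1` — 0%

In a functional assay on the whole organism for inhibition, with Mus musculus as the target, in the writhing test, with stated times of 30 min and 4 h, at a dose of 25 mg/kg by the intraperitoneal route (on this read-out higher numbers stand for more inhibition at the one dose given (going by the name of the read-out) and lower numbers for less inhibition), compound 1 gives 0%. Compound 3 shows no change from this within the scatter, and these two are together the lowest of the three numbers. Compound 2 gives 20%, and this number stands higher than that of compound 1, a difference that lies outside the scatter.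

Compound 4 `COc1ccc(-c2c(C)c(C(=O)O)nn2-c2ccc(Cl)cc2)c(OC)c1` is the next member to be measured. It differs from compound 1 by hydrogen in place of ethyl on an oxygen next to a carbonyl group. For the measured compounds named here, no step between measured compounds covers this kind of change, so there is nothing to set its size. The step from compound 1 to compound 4 is expected to be small, a number 10 percentage points higher from compound 1 to compound 4 (within the scatter), either none beyond the scatter or a modest rise. Compound 4 is accordingly estimated at 10%, with a range from 0% to 35%.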

Compound 4, a percentage reported as inhibition, in the whole organism at one dose (the size of the read-out at that dose, not a potency): 0%
The estimate for compound 4 lay 10 percentage points above the measured number; measured number inside the range.
By their numbers in this assay, from the lowest: compounds 1, 3 and 4 (each within the scatter of the next); then compound 2.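

Hydrogen in place of ethyl on an oxygen next to a carbonyl group gives no change at the digits printed from compound 1 to compound 4 (within the scatter) in this assay. For the compounds shown here, this is the first step read at this position, and on this read-out the ethoxycarbonyl and carboxy forms do not separate. No measurement at hand bears on this result.

As far as these compounds go, whether an amide in place of the ester, or a longer chain such as butyl on this oxygen, would separate from compound 1 stays open. From the compounds shown here alone, whether the same change behaves alike on another core also stays open.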